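A few compounds are considered here, and "the series" means these few. Any claim that something is new, unique, unknown or untested is made for them only; others in the source may bear on it.

Compound 2 `CCCCCCCOc1ccc(CCC(N)(CO)CCCC)cc1` has been measured in a functional assay on the whole organism (spleen, spleen) with Rattus norvegicus as the target; a higher number here means that more compound is needed for the effect, a lower number that less compound is needed; its result there, > 10 mg/kg, is only a limit of the assay and not a number. Compound 1 `CCCCCCCOc1ccc(CCC(N)(CO)CCC)cc1` gives 7.3 mg/kg in this assay. Within the data shown here, the single measured step, an at least 1.3-fold higher number from compound 1 to compound 2 (0.13 log units; that floor lies within the scatter), ends at the point described by the limit of > 10 mg/kg in this assay, at which 1 of the 2 values shown sits. Compound 3 `CCCCCCCOc1ccc(CC[C@](N)(CO)CCO)cc1` differs from compound 2 by a group of 7 heavy atoms (4 carbon, 1 nitrogen, 2 oxygen; no ring) in place of a group of 8 heavy atoms (6 carbon, 1 nitrogen, 1 oxygen; no ring), on a saturated chain carbon, two bonds along the chain from an aromatic carbon. Among the measured compounds shown here, no measured step covers a change of this kind, so its direction and size are open, and the estimate below carries wide uncertainty. For compound 3 the expected dose is 8 mg/kg, with a range from 2 mg/kg to 30 mg/kg. The step this expectation implies is an at least 1.2-fold lower number from compound 2 to compound 3 (0.09 log units; that floor lies within the scatter).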

Compound 3, dose for 50% inhibition: 4.2 mg/kg
Compound 3: the middle estimate sits 1.9-fold (0.28 log units) above what was measured; low and high end bracket the measured number.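

Among these compounds, at this place, on a saturated chain carbon, the oxygen-bearing group of compound 3 gives a real number in this assay, with an at least 2.3-fold lower number from compound 2 to compound 3 (0.37 log units; beyond the scatter) as the first step here beyond the scatter. That step is only a floor, and the value of compound 2 is a limit of the assay and not a number: the limit of > 10 mg/kg in this assay, at which 1 of the 3 values shown sits. Against the group of equal heavy-atom count in compound 1, the result is a 1.7-fold lower number from compound 1 to compound 3 (0.24 log units; within the scatter), so those two compounds cannot be told apart.

The compounds shown do not separate the added oxygen from the defined stereocentre. They also leave open how a carboxylic acid or an amine would fare at this place.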